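The compounds below may be only part of what the source reports. "The series", "measured", "known", "first", "only" and "open" are said of these compounds alone.

Compound 2 `COc1cc(OC)c(-c2coc3cc(OCc4ccc([N+](=O)[O-])cc4)ccc3c2=O)cc1OC` is one of three compounds that share one core and differ only in the group hanging from a saturated chain carbon bound to an oxygen on an aromatic ring. In a functional assay on HepG2 cells (Homo sapiens) for antiproliferative activity, read by MTT assay, with a stated time of 24 h (a higher number here means a weaker inhibitor, a lower number a stronger inhibitor), compound 2 gives 2500 nM. Compound 1 `C#CCOc1ccc2c(=O)c(-c3cc(OC)c(OC)cc3OC)coc2c1` gives 4950 nM, and compound 3 `COc1cc(OC)c(-c2coc3cc(OCc4ccc(C#N)cc4)ccc3c2=O)cc1OC` gives 4230 nM. Of the three numbers, that of compound 2 is the smallest, yet the gaps to the others are not beyond the scatter: a 2.0-fold lower number from compound 1 to compound 2 (0.30 log units; within the scatter) and a 1.7-fold higher number from compound 2 to compound 3 (0.23 log units; within the scatter).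

Compound 4 `COc1cc(OC)c(-c2coc3cc(OCc4ccc(C(F)(F)F)cc4)ccc3c2=O)cc1OC` is not yet measured. Its change from compound 2 is trifluoromethyl in place of nitro on an aromatic carbon. The step that bears most on it is the exchange of one group for another at the same aromatic carbon, a 1.7-fold higher number from compound 2 to compound 3 (0.23 log units; within the scatter), which stayed within the scatter, as did a 1.2-fold lower number from compound 1 to compound 3 (0.07 log units; within the scatter). Within the data shown here, no measured step involves trifluoromethyl, so nothing here points to a shift beyond the scatter.

Compound 4 is therefore expected to give about 3000 nM in this assay, in the range 1400 nM to 6500 nM. This estimate means a step of a 1.2-fold higher number from compound 2 to compound 4 (0.08 log units; within the scatter), expected to be no more than the scatter.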

Compound 4, half-maximal inhibitory concentration: 890 nM
Compound 4: middle estimate off by 3.4-fold (0.53 log units), on the high side, outside the stated range (below it).
By their numbers in this assay, from the lowest: compound 4; then compounds 2, 3 and 1 (each within the scatter of the next).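

In this assay the aromatic carbon that holds the nitro group of compound 2 proves sensitive to what sits on it, since trifluoromethyl there gives a 2.8-fold lower number from compound 2 to compound 4 (0.45 log units; beyond the scatter) and, against the nitrile, a 4.8-fold lower number from compound 3 to compound 4 (0.68 log units; beyond the scatter) while the earlier exchange of nitro for cyano stayed within the scatter. The change at the chain carbon also now reaches beyond the scatter, with 4-(trifluoromethyl)phenyl in place of ethynyl giving a 5.6-fold lower number from compound 1 to compound 4 (0.75 log units; beyond the scatter) where the 4-nitrophenyl and 4-cyanophenyl groups did not. Nothing available explains why trifluoromethyl stands apart from nitro and cyano.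

Going by these compounds, whether a chlorine atom, a methoxy group or an amine on the same aromatic carbon would match compound 4 remains open. So does whether trifluoromethyl would keep this effect on a different carbon of that ring.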